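Series notes: hydroxyethyl substitution on the thiophene carbon

The source may hold more compounds than are shown below. What is called first, only, known or untested is meant among the compounds shown, and "the series" means these compounds.

The shared core of compound 1 `CCC(O)(c1cn(Cc2ccc3c(-c4ccccc4)csc3c2)nn1)C(F)(F)F` carries a phenyl group on the fused five-membered sulfur ring, and in an assay on isolated protein for inhibition of Polyunsaturated fatty acid 5-lipoxygenase (Homo sapiens) (on this read-out lower numbers stand for stronger inhibition and higher numbers for weaker inhibition), compound 1 gives 40 nM. This is the higher of the two numbers recorded so far. Compound 2 `CC[C@](O)(c1cn(Cc2ccc3c(-c4cccc(F)c4)c(C(N)=O)sc3c2)nn1)C(F)(F)F` gives 39 nM in this assay, a value that sits within the scatter of the number for compound 1, so the two compounds cannot be told apart on this read-out.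

Compound 3 `CCC(O)(c1cn(Cc2ccc3c(-c4ccccc4)c(C(C)O)sc3c2)nn1)C(F)(F)F` is the next compound to be measured in this assay. Relative to compound 1 the change is 1-hydroxyethyl in place of hydrogen on an aromatic carbon. Going by the values given here, no step between measured compounds covers this change, so nothing directly shows how this position responds.

Given that compound 2, which also carries a substituent on the same ring, gives 39 nM, a step of small size or none beyond the scatter is expected, with a slight lean toward a lower number: a 1.2-fold lower number from compound 1 to compound 3 (0.08 log units; within the scatter). Compound 3 is therefore estimated at 33 nM, in a range from 12 nM to 95 nM.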

Compound 3, half-maximal inhibitory concentration: 88 nM
Compound 3: middle estimate off by 2.7-fold (0.43 log units), on the low side; the range from low to high includes it.
By their numbers in this assay, from the lowest: compounds 2 and 1 (each within the scatter of the next); then compound 3.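

The aromatic carbon next to the ring sulfur and next to the ring atom that bears a phenyl group now has its first direct reading: in this assay, 1-hydroxyethyl in place of hydrogen gives a 2.2-fold higher number from compound 1 to compound 3 (0.34 log units; beyond the scatter). The position therefore responds to this change, although the step is modest and compound 3 remains measurable at 88 nM. Going by these compounds alone, compound 2 differs from compound 1 in more than one place, so only this single step isolates the position, and no measurement at hand accounts for its direction or size.

One substituent cannot show whether the higher number belongs to the hydroxyl or to the two-carbon chain that carries it, and an ethyl group at the same carbon would separate the two. Also open, going by these compounds, is how this position responds to other groups such as an amine, a carboxylic acid or a longer chain, and whether the step from 1-hydroxyethyl holds on a core with a different group in place of the phenyl.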